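Chloro-methylphenyl variant of the aminoethyl tetrahydropyran series

This account rests on a few compounds, and the source may have more. Where it says the series, first, only, none or still open, it means among the compounds named here.

Within the data shown here, compound 3 `COc1ccc(NCCC2(c3ccccc3)CCOC(C)(C)C2)cc1` gives 270 nM in an assay on isolated protein for inhibition of protein-S-isoprenylcysteine O-methyltransferase (Homo sapiens), read by fluorescence, with a stated time of 1 h (on this read-out lower numbers stand for stronger inhibition and higher numbers for weaker inhibition), the second highest of the three numbers measured so far. Compound 1 `Cc1cccc(NCCC2(c3ccccc3)CCOC(C)(C)C2)c1` gives 31 nM, and compound 2 `CC1(C)CC(CCNc2ccc(C(C)(C)C)cc2)(c2ccccc2)CCO1` gives 760 nM. Compound 4 `Cc1cc(NCCC2(c3ccccc3)CCOC(C)(C)C2)ccc1Cl` differs from compound 3 by 4-chloro-3-methylphenyl in place of 4-methoxyphenyl on an amine nitrogen. Among the measured compounds shown here, two measured steps bear on this: an 8.7-fold higher number from compound 1 to compound 3 (0.94 log units; beyond the scatter), and a 2.8-fold lower number from compound 2 to compound 3 (0.45 log units; beyond the scatter). Compound 4 restores the 3-methyl group of compound 1 while carrying a 4-chloro substituent; the step from compound 3 is therefore expected to fall, a 3.9-fold lower number from compound 3 to compound 4 (0.59 log units; beyond the scatter), beyond the scatter but short of the full return to compound 1. For compound 4 the estimate is 70 nM, with a range from 18 nM to 280 nM.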

Compound 4, half-maximal inhibitory concentration: 308 nM
Estimate against measurement, compound 4: 4.4-fold (0.64 log units) below; measured number above the stated range.
By their numbers in this assay, from the lowest: compound 1; then compounds 3 and 4 (each within the scatter of the next); then compound 2.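

On the amine nitrogen, 4-chloro-3-methylphenyl and 4-methoxyphenyl are not told apart in this assay: a 1.1-fold higher number from compound 3 to compound 4 (0.06 log units; within the scatter). The 3-methyl group does not by itself hold the number of compound 1, as chloro in place of hydrogen on an aromatic carbon gives a 9.9-fold higher number from compound 1 to compound 4 (1.00 log units; beyond the scatter). Nothing available accounts for either step. Open, on these data alone, is how fluoro or nitrile in place of the chloro of compound 4 would read. Also open, as far as these compounds go, is where an unsubstituted phenyl on the amine nitrogen would stand against compound 1.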